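Acetyl Removal on Two Related Cores: Expected Cytotoxicity

The source may report more compounds than this note shows. Statements on the series, on what has been measured and on what is new or still open speak of the compounds shown alone.

Measured compounds:
compound 1, `C=C1CC[C@@H]2[C@](C)(CO[Si](C)(C)C(C)(C)C)[C@H](OC(C)=O)CC[C@@]2(C)[C@@H]1C/C=C1/C(=O)OC[C@H]1OC(C)=O`: 0.34 uM
compound 2, `C=C1CC[C@@H]2[C@](C)(CO[Si](C)(C)C(C)(C)C)[C@H](O)CC[C@@]2(C)[C@@H]1C/C=C1/C(=O)OC[C@H]1OC(C)=O`: 1.03 uM
compound 3, `C=C1CC[C@@H]2[C@](C)(CO[Si](c3ccccc3)(c3ccccc3)C(C)(C)C)[C@H](OC(C)=O)CC[C@@]2(C)[C@@H]1C/C=C1/C(=O)OC[C@H]1OC(C)=O`: 1.67 uM

Of the compounds shown here, three have been tested in a functional assay on P388 cells (Mus musculus) for cytotoxicity, read by sulforhodamine B assay; on this read-out lower numbers stand for an effect already at smaller amounts and higher numbers for an effect only at larger amounts of compound. Compound 1 and compound 2 share one core and differ in a single place: hydrogen in place of acetyl on an oxygen on a saturated carbon. This change made a step of a 3.0-fold higher number from compound 1 to compound 2 (0.48 log units; beyond the scatter).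

Compound 3 carries a different core; the difference between the core of compound 1 and the core of compound 3 is not broken down here. In this assay compound 3 gives 1.67 uM, the highest of the three numbers, though its gap to compound 2 lies within the scatter, while its gap to compound 1 lies beyond it.

Compound 4, `C=C1CC[C@@H]2[C@](C)(CO[Si](c3ccccc3)(c3ccccc3)C(C)(C)C)[C@H](O)CC[C@@]2(C)[C@@H]1C/C=C1/C(=O)OC[C@H]1OC(C)=O`, has not yet been measured. It differs from compound 3 in the same way that compound 2 differs from compound 1: hydrogen in place of acetyl on an oxygen on a saturated carbon. The place of the change, an oxygen on a saturated carbon whose other neighbour is a saturated ring carbon, is the same in words for both pairs, so the change is the same change on a different core. If the step from compound 3 to compound 4 in this assay resembles the one from compound 1 to compound 2, compound 4 is expected to give a higher number than compound 3, because a 3.0-fold higher number from compound 1 to compound 2 (0.48 log units; beyond the scatter) was seen on the other core. The expected step for compound 4 is a 2.7-fold higher number from compound 3 to compound 4 (0.43 log units; beyond the scatter). For compound 4 the estimate in this assay is 4.5 uM, with a range from 2 uM to 12 uM expected to cover most repeat measurements. This rests on one matched pair only, so the direction is more secure than the exact size.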

Compound 4, concentration for half-maximal effect: 0.33 uM
Beside the measured number, compound 4's estimate is 14-fold (1.13 log units) above it; measured number outside the range, below it.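

In this assay, the change from acetoxy to hydroxy on the core of compound 3 gave a 5.1-fold lower number from compound 3 to compound 4 (0.70 log units; beyond the scatter), a step in the opposite direction to the one seen on the core of compound 1. Set side by side, the two steps show that, in this series, the effect of removing this acetyl did not carry from one core to the other, in direction or in size: the same change on two cores in this assay, a 3.0-fold higher number (0.48 log units; beyond the scatter) from compound 1 to compound 2 and a 5.1-fold lower number (0.70 log units; beyond the scatter) from compound 3 to compound 4, 15-fold (1.19 log units) apart, beyond the scatter of two such steps

For the compounds shown here, with only one matched pair on each core, this does not show why the two steps part, which feature of the cores is responsible, or how the same change would behave on any further core. The compounds shown leave open how other groups on that oxygen, such as a benzoyl group or a methyl ether, would read in this assay on either core. They also leave open whether a step on a further core would follow the one on the core of compound 1, the one on the core of compound 3, or neither.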